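Chloro for fluoro on the phenylsulfonyl group

The compounds below may be only part of what the source reports. "The series", "measured", "known", "first", "only" and "open" are said of these compounds alone.

Compound 1 (`Cc1ccc(-c2nn(-c3ccccc3)cc2-c2nc3ccccc3n2S(=O)(=O)c2ccc(Cl)cc2)cc1`), compound 2 (`COc1ccc(S(=O)(=O)n2c(-c3cn(-c4ccccc4)nc3-c3ccc(C(F)(F)F)cc3)nc3ccccc32)cc1`) and compound 3 (`O=S(=O)(c1ccc(F)cc1)n1c(-c2cn(-c3ccccc3)nc2-c2ccc(C(F)(F)F)cc2)nc2ccccc21`) have been measured so far. In a functional assay on HeLa cells (Homo sapiens) for antiproliferative activity, read by MTT assay, with a stated time of 24 h (a lower number here means a stronger inhibitor, a higher number a weaker inhibitor), compound 3 gives 2190 nM and lies within the scatter of compound 1 (4060 nM), while compound 2 (250 nM) stands well apart from it.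

Compound 4 (`O=S(=O)(c1ccc(Cl)cc1)n1c(-c2cn(-c3ccccc3)nc2-c2ccc(C(F)(F)F)cc2)nc2ccccc21`) puts chloro in place of fluoro on an aromatic carbon, para to a large group (chloro in place of fluoro on an aromatic carbon). This turns the (4-fluorophenyl)sulfonyl group into (4-chlorophenyl)sulfonyl.

Among the measured compounds shown here, the one measured step at this place (an 8.8-fold higher number from compound 2 to compound 3 (0.94 log units; beyond the scatter)) is modest and beyond the scatter. It exchanges methoxy for fluoro, however, and sets no direction for an exchange of fluoro for chloro. Compound 1 already carries the (4-chlorophenyl)sulfonyl group, but it also differs from compound 4 elsewhere and offers no clean comparison. For the measured compounds named here, no measured pair compares the two halogens directly.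

No step beyond the scatter is therefore expected in this assay and no firm direction can be assigned. The estimated step (a 1.2-fold lower number from compound 3 to compound 4 (0.09 log units; within the scatter)) is small and expected to stay within the scatter. Compound 4 is expected at 1800 nM with a wide estimated range (600 nM to 5000 nM).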

Compound 4, half-maximal inhibitory concentration: 3060 nM
Beside the measured number, compound 4's estimate is 1.7-fold (0.23 log units) below it; the measured number falls inside the stated range.
By their numbers in this assay, from the lowest: compound 2; then compounds 3, 4 and 1 (each within the scatter of the next).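

In this assay, the direct comparison of the halogens, a 1.4-fold higher number from compound 3 to compound 4 (0.15 log units; within the scatter), stays within the scatter, so chloro and fluoro cannot be told apart at this place on the phenylsulfonyl group. With the trifluoromethyl compounds alone, methoxy is now set apart from both halogens: an 8.8-fold higher number from compound 2 to compound 3 (0.94 log units; beyond the scatter) is joined by a 12-fold higher number from compound 2 to compound 4 (1.09 log units; beyond the scatter), and the large step at this place therefore belongs to the loss of methoxy rather than to the identity of the halogen. The other position also gains a clean comparison with the (4-chlorophenyl)sulfonyl group held fixed, where a 1.3-fold lower number from compound 1 to compound 4 (0.12 log units; within the scatter) shows that trifluoromethyl in place of methyl does not move the number beyond the scatter.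

Going by these compounds, whether the low number of compound 2 is particular to methoxy remains open, as ethoxy, a longer alkoxy chain, hydroxy or an amine at this place could separate from methoxy or join it, and whether methoxy keeps its gap alongside methyl rather than trifluoromethyl is equally unsettled. Nothing available explains the difference between methoxy and the halogens.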